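The compounds below may be only part of what the source reports. "The series", "measured", "known", "first", "only" and "open" are said of these compounds alone.

Three compounds share one core and differ only in the aromatic group on a saturated chain carbon bound to an aromatic carbon and an oxygen. In a functional assay on Caco-2 cells (Homo sapiens) for inhibition, read by MTT assay, with a stated time of 48 h, tested at 10 uM (on this read-out lower numbers stand for less inhibition of growth and higher numbers for more inhibition of growth at the one concentration tested), compound 1 `Cc1oc2c([C@H]3CCN(C)C[C@H]3O)c(O)cc(O)c2c(=O)c1C(O)c1ccc([N+](=O)[O-])cc1`, with a 4-nitrophenyl group, gives 5%. Compound 2 `Cc1oc2c([C@H]3CCN(C)C[C@H]3O)c(O)cc(O)c2c(=O)c1C(O)c1ccccc1Br` gives 7%, and compound 3 `Cc1oc2c([C@H]3CCN(C)C[C@H]3O)c(O)cc(O)c2c(=O)c1C(O)c1cccc(Cl)c1Cl` gives 3%. Compound 3 therefore stands level with the other two, since every gap is within the scatter: the steps are a number 2 percentage points lower from compound 1 to compound 3 (within the scatter), a number 4 percentage points lower from compound 2 to compound 3 (within the scatter) and a number 2 percentage points higher from compound 1 to compound 2 (within the scatter). So far, exchanging this group has produced no measurable difference.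

The next structure is compound 4 `Cc1oc2c([C@H]3CCN(C)C[C@H]3O)c(O)cc(O)c2c(=O)c1C(O)c1ccc(F)cc1`, which has 4-fluorophenyl in place of 2,3-dichlorophenyl at that same carbon: 4-fluorophenyl in place of 2,3-dichlorophenyl on a saturated chain carbon bound to an aromatic carbon and an oxygen on a saturated carbon. Going by the values given here, no measured compound carries this group, so the evidence is indirect. Still, the three measured steps are changes at the same place, and compound 1 already shows a group named at the 4 position of the ring giving 5%. On that basis, no step beyond the scatter is expected in this assay, and the expected step is a number 3 percentage points higher from compound 3 to compound 4 (within the scatter). For compound 4 the estimated value is 6%, with an expected range from 0% to 16%.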

Compound 4, percent growth inhibition at one concentration: 11%
Compound 4: the middle estimate sits 5 percentage points below what was measured, within the range that was stated.
By their numbers in this assay, from the lowest: compounds 3, 1, 2 and 4 (each within the scatter of the next).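

In this assay the fourth aromatic group keeps the set level: a number 8 percentage points higher from compound 3 to compound 4 (within the scatter), a number 4 percentage points higher from compound 2 to compound 4 (within the scatter) and a number 6 percentage points higher from compound 1 to compound 4 (within the scatter), so exchanging the group on this saturated chain carbon still produces no measurable difference. The last of these steps is the narrowest change in the set, fluoro in place of nitro on an aromatic carbon with the rest of the molecule untouched, and even this direct swap of one ring substituent for another stays inside the scatter. Nothing measured here offers an explanation for the small gaps among these four compounds, or shows that they carry any meaning.

As far as these compounds go, all four groups are phenyl rings carrying a halogen or a nitro group, so it remains open whether an amine or a carboxylic acid on that ring, or a longer chain in place of the ring, would move the number beyond the scatter. From the compounds shown here alone, with all four compounds read at one concentration in one cell line, it also remains open whether they would separate at other concentrations or in other cells.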